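Halogen swaps on two rings of a shared core

The compounds below may be only part of what the source reports. "The series", "measured", "known", "first", "only" and "open" are said of these compounds alone.

Compound 1 `O=S(=O)(NCCCNc1nccc(-c2[nH]c(-c3ccccc3)nc2-c2ccc(F)c(O)c2)n1)c1ccc(Cl)cc1` is the reference point of the series. In a functional assay on LOX IMVI cells (Homo sapiens) for cytotoxicity, read by MTT assay, with a stated time of 24 h (on this read-out higher numbers stand for weaker inhibition and lower numbers for stronger inhibition), compound 1 gives 14200 nM. Compound 2 `O=S(=O)(NCCCNc1nccc(-c2[nH]c(-c3ccccc3)nc2-c2ccc(F)c(O)c2)n1)c1ccc(Br)cc1` carries bromo in place of chloro on an aromatic carbon; in this assay compound 2 gives 5660 nM, and the step is a 2.5-fold lower number from compound 1 to compound 2 (0.40 log units; beyond the scatter). Compound 3 `O=S(=O)(NCCCNc1nccc(-c2[nH]c(-c3ccccc3)nc2-c2ccc(Cl)c(O)c2)n1)c1ccc(Cl)cc1` differs from compound 1 in the core: chloro in place of fluoro on an aromatic carbon. In this assay compound 3 gives 61300 nM, the highest number of the three, with the step of a 4.3-fold higher number from compound 1 to compound 3 (0.64 log units; beyond the scatter). Compound 4 `O=S(=O)(NCCCNc1nccc(-c2[nH]c(-c3ccccc3)nc2-c2ccc(Cl)c(O)c2)n1)c1ccc(Br)cc1` is not yet measured; it differs from compound 3 by bromo in place of chloro on an aromatic carbon. Going by the values given here, this is the same change as the one from compound 1 to compound 2, and the place is described in the same words in both cases, so it is the same change set on a core that differs as described. Among the compounds shown the change appears in two pairs, one of them measured. For compound 4 in this assay the expected step is a 2.5-fold lower number from compound 3 to compound 4 (0.39 log units; beyond the scatter), taken as comparable to the earlier one because the measured pair gave a 2.5-fold lower number from compound 1 to compound 2 (0.40 log units; beyond the scatter). This rests on a single pair, and the core of compound 3 sits well above that of compound 1, so the size may not carry over exactly. The estimate for compound 4 in this assay is 25000 nM, with a range from 10000 nM to 62000 nM.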

Compound 4, half-maximal inhibitory concentration: 15500 nM
Compound 4: middle estimate off by 1.6-fold (0.21 log units), on the high side, within the range that was stated.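

In this assay, the change from 4-chlorophenyl to 4-bromophenyl gives a 4.0-fold lower number from compound 3 to compound 4 (0.60 log units; beyond the scatter), in the same direction as on the core of compound 1, and the two sizes do not separate: the same change on two cores in this assay, a 2.5-fold lower number (0.40 log units; beyond the scatter) from compound 1 to compound 2 and a 4.0-fold lower number (0.60 log units; beyond the scatter) from compound 3 to compound 4, 1.6-fold (0.20 log units) apart, within the scatter of two such steps. Chloro in place of fluoro on the core, read with bromo on the other ring, gives a 2.7-fold higher number from compound 2 to compound 4 (0.44 log units; beyond the scatter), which also agrees in direction and size with the earlier step: the same change on two cores in this assay, a 4.3-fold higher number (0.64 log units; beyond the scatter) from compound 1 to compound 3 and a 2.7-fold higher number (0.44 log units; beyond the scatter) from compound 2 to compound 4, 1.6-fold (0.20 log units) apart, within the scatter of two such steps. Within the scatter, each of the two changes carries over from one core to the other across these four compounds, but this rests on a single set of two halogens at each of two places, and it shows neither whether the agreement holds on other cores nor why either change moves the number.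

The compounds shown leave open what happens with a group other than chloro or bromo on the sulfonyl-bearing ring, such as a methoxy group or a nitrile, and with iodo in that place. They also leave open whether the same steps hold with a longer chain in the linker or with a hydrogen in place of the halogen on the core.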